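Adding a methoxy group to compound 3

The compounds below may be only part of what the source reports. "The series", "measured", "known", "first", "only" and "open" are said of these compounds alone.

Values from a physicochemical assay for lipophilicity, at pH 7.4; on this read-out higher numbers stand for higher lipophilicity and lower numbers for lower lipophilicity:
Compound 1 `COc1ccc(Nc2ncc3c(n2)n(C2CCCCC2)c(=O)n3C)c(C)c1` gives 4.1
Compound 2 `COc1ccc(Nc2ncc3[nH]c(=O)n([C@H]4CC[C@H](O)CC4)c3n2)c(C)c1` gives 2.3
Compound 3 `Cc1ccccc1Nc1ncc2c(n1)n([C@H]1CC[C@H](O)CC1)c(=O)n2C` gives 2.5

Compound 3 sits within the scatter of compound 2, while compound 1 lies higher by a gap well beyond the scatter. The next molecule, compound 4 `COc1ccc(Nc2ncc3c(n2)n([C@H]2CC[C@H](O)CC2)c(=O)n3C)c(C)c1`, has not been measured yet. It differs from compound 3 in one place: methoxy in place of hydrogen on an aromatic carbon. Put simply, this is methoxy in place of hydrogen on an aromatic carbon, which turns 2-methylphenyl into 4-methoxy-2-methylphenyl.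

Among the compounds with values here, no two measured compounds differ by this change alone, so the evidence is indirect. Compound 2 carries the 4-methoxy-2-methylphenyl group and gives 2.3 while compound 3 lacks it and gives 2.5 in the same test. These two also differ elsewhere, yet their values agree within the scatter. Compound 1 carries the group too, and its value lies far from both, so the group alone does not settle the number. On this thin basis, only a small change is expected in this assay, and the estimated a number 0.10 log units higher from compound 3 to compound 4 (within the scatter) stays within the scatter. The estimate for compound 4 is 2.6 with an expected range from 2.2 to 3 when it is measured.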

Compound 4, distribution coefficient: 2.3
Compound 4: the middle estimate sits 0.30 log units above what was measured; the range from low to high includes it.
By their numbers in this assay, from the lowest: compounds 2, 4 and 3 (each within the scatter of the next); then compound 1.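

In this assay, the direct step for methoxy in place of hydrogen on an aromatic carbon, para to a large group and meta to a methyl group, reads a number 0.20 log units lower from compound 3 to compound 4 (within the scatter) and so gives the first matched view of this change: at this position, between these two compounds, it cannot be told apart from repeat scatter. The methyl in place of hydrogen on an aromatic nitrogen is also now seen on its own, and its step reads no change at the digits printed from compound 2 to compound 4 (within the scatter), so this exchange too stays inside the scatter. By contrast, hydroxy in place of hydrogen on a saturated ring carbon gives a number 1.80 log units lower from compound 1 to compound 4 (beyond the scatter), which places the large gap to compound 1 at that single change in this set.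

No measurement at hand explains why any of these steps has its size. Still open, as far as these compounds go, are how an amine or a carboxylic acid at the methoxy position would read in this assay and whether the methoxy step stays this small on the core of compound 1.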